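The source may report more compounds than this note shows. Statements on the series, on what has been measured and on what is new or still open speak of the compounds shown alone.

In a functional assay on HepG2 cells (Homo sapiens) for cytotoxicity, read by MTT assay, with a stated time of 6 h (on this read-out higher numbers stand for weaker inhibition and lower numbers for stronger inhibition), compound 1 `O=S(=NSC(F)(F)F)(c1ccccc1)N1CCCC1` gives 15 ug/mL and compound 2 `O=S(=NSC(F)(F)F)(c1ccccc1)c1ccccc1` gives 90 ug/mL, the higher of the two numbers. Compound 3 `O=S(=NC(F)(F)F)(c1ccccc1)c1ccccc1` carries trifluoromethyl in place of (trifluoromethyl)sulfanyl on a sulfonamide nitrogen. Going by the values given here, the only measured step, a 6.0-fold higher number from compound 1 to compound 2 (0.78 log units; beyond the scatter), was a change on the sulfinyl sulfur, so it bears on this change only indirectly and gives just a rough size for a single change. No step beyond the scatter is expected in this assay. The expected step is a 1.3-fold lower number from compound 2 to compound 3 (0.11 log units; within the scatter). For compound 3 the estimated value is 70 ug/mL, with an expected range from 25 ug/mL to 200 ug/mL.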

Compound 3, half-maximal inhibitory concentration: 200 ug/mL
Compound 3: the middle estimate sits 2.9-fold (0.46 log units) below what was measured, and the stated range covers the measured number.
By their numbers in this assay, from the lowest: compound 1; then compound 2; then compound 3.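

In this assay, the group on the sulfonamide nitrogen also moves the read-out, which the earlier pair could not show, since it differed only on the sulfinyl sulfur. Trifluoromethyl in place of (trifluoromethyl)sulfanyl gives weaker inhibition (a 2.2-fold higher number from compound 2 to compound 3 (0.35 log units; beyond the scatter)), a step beyond the scatter. Nothing available accounts for this step. As far as these compounds go, it remains open whether the same change would act alike with pyrrolidin-1-yl on the sulfinyl sulfur. From the compounds shown here alone, it also remains open what a methyl or acetyl group on that nitrogen would give.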